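The compounds below may be only part of what the source reports. "The series", "measured", "known", "first", "only" and "open" are said of these compounds alone.

For the measured compounds named here, in a functional assay on OCI-Ly3 cells (Homo sapiens) for antiproliferative activity (a higher number here means that more compound is needed for the effect, a lower number that less compound is needed), compound 1 (`CC(C)c1c(NC(=O)Nc2cnc(-n3nccn3)c(Cl)c2)cnc2ccccc12`) gives 2420 nM as the only number in the set. Compound 2 (`O=C(Nc1cnc(-n2nccn2)c(Cl)c1)Nc1cnc2cc(Cl)ccc2c1C1CC1`) gives > 20000 nM as a limit only. Compound 3 (`COc1ccc2c(C3CC3)c(NC(=O)Nc3cnc(-n4nccn4)c(Cl)c3)cnc2c1`) gives > 20000 nM as a limit only. Compound 4 (`COC(C)c1c(NC(=O)Nc2cnc(-n3nccn3)c(Cl)c2)cnc2ccccc12`) differs from compound 1 by methoxy in place of methyl on a saturated chain carbon bound to an aromatic carbon and a saturated chain carbon with isopropyl becoming 1-methoxyethyl. Going by the values given here, the sole measured step, a step that the two limits leave unreadable from compound 2 to compound 3 on an aromatic carbon, gives no size for this change, so no shift beyond the scatter is expected in this assay for compound 4. The estimated step is a 1.2-fold lower number from compound 1 to compound 4 (0.08 log units; within the scatter) and no more. For compound 4 the expected value is 2000 nM within an estimated range of 400 nM to 10000 nM in this assay.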

Compound 4, half-maximal effective concentration: 620 nM
Compound 4: the middle estimate sits 3.2-fold (0.51 log units) above what was measured; measured number inside the range.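

Isopropyl to 1-methoxyethyl is the first change in this series with a readable size in this assay: a 3.9-fold lower number from compound 1 to compound 4 (0.59 log units; beyond the scatter). The only other step, between compound 2 and compound 3, cannot be read, so this saturated chain carbon is the one place where a change in the number is shown. Nothing available on these compounds accounts for the step.

Left open is whether methoxy itself carries the shift, as a hydroxyl, an ethoxy or an amine at this carbon would show. Also open, as far as these compounds go, is whether the shift holds on other versions of the shared core.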